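Swapping Methoxy for Nitro on a Shared Core

This account rests on a few compounds, and the source may have more. Where it says the series, first, only, none or still open, it means among the compounds named here.

Compound 2 `COc1ccc(-c2csc(N3N=C(c4ccc(Cl)s4)CC3c3ccc(F)cc3)n2)cc1` shares much of its structure with compound 1 `Cc1ccc(C2=NN(c3nc(-c4ccc([N+](=O)[O-])cc4)cs3)C(c3ccc(F)cc3)C2)s1`. In a functional assay on A549 cells (Homo sapiens) for antiproliferative activity, read by XTT assay, with a stated time of 24 h (on this read-out higher numbers stand for weaker inhibition and lower numbers for stronger inhibition), compound 1 gives 16.7 ug/mL. For compound 2 this assay reports only a limit rather than a number, > 500 ug/mL, which is the limit of > 500 ug/mL in this assay, at which 1 of the 2 values shown sits. Compound 3 `O=[N+]([O-])c1ccc(-c2csc(N3N=C(c4ccc(Cl)s4)CC3c3ccc(F)cc3)n2)cc1` carries nitro in place of methoxy on an aromatic carbon. For the measured compounds named here, no measured pair isolates this change, so the expectation leans on compound 1, whose nitro-bearing structure gives 16.7 ug/mL. The step from compound 2 to compound 3 is expected to be an at least 10-fold lower number from compound 2 to compound 3 (1.00 log units; beyond the scatter), towards stronger inhibition. Compound 3 is expected to give roughly 50 ug/mL, between 10 ug/mL and 400 ug/mL.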

Compound 3, half-maximal inhibitory concentration: > 500 ug/mL
Compound 3: only a limit was reported; the forecaster's own chance of this, stated with the estimate: 25%; middle value at least 10-fold (1.00 log units) from the limit.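

With the nitro group in place, compound 3 still gives only a limit in this assay, so nitro alone does not yield a readable number on this core. Chloro in place of methyl on an aromatic carbon gives an at least 29-fold higher number from compound 1 to compound 3 (1.47 log units; beyond the scatter), towards weaker inhibition. The methoxy-to-nitro step cannot be read, and the two compounds share one limit: the limit of > 500 ug/mL in this assay, at which 2 of the 3 values shown sit.

Still open, on these data alone, is how methoxy behaves with methyl rather than chloro. Also open, as far as these compounds go, is whether an amine in place of nitro, or bromo in place of chloro, would give a number rather than a limit.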